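Hydroxymethyl for methoxy in a small amide

A few compounds are considered here, and "the series" means these few. Any claim that something is new, unique, unknown or untested is made for them only; others in the source may bear on it.

Three compounds have been measured in an assay for inhibition of alcohol dehydrogenase (Equus caballus); on this read-out higher numbers stand for weaker inhibition and lower numbers for stronger inhibition:

compound 1 `COCC(N)=O` gives 600000 nM
compound 2 `CC(C)C[S+](C)[O-]` gives 340000 nM
compound 3 `C[S+]([O-])Cc1ccccc1` gives 5000000 nM

In this assay compound 1 stands second highest of the three numbers. Its nearest neighbour is compound 2, whose number lies within the scatter of that of compound 1, so no order between these two can be claimed. Compound 3 stands furthest away, with a number beyond the scatter above that of compound 1. Within the data shown here, no step between two measured compounds differing in one place is available, so the effect of a single change remains unknown.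

Compound 4 `NC(=O)CCO` has not yet been measured. It differs from compound 1 in one place: hydroxymethyl in place of methoxy on a saturated chain carbon bound to a carbonyl carbon. Among the measured compounds shown here, with no comparable step among the measured compounds, the expected step of a 1.2-fold higher number from compound 1 to compound 4 (0.07 log units; within the scatter) in this assay is small and not clearly beyond the scatter in either direction. Compound 4 is therefore expected to give about 700000 nM, with a range from 200000 nM to 2500000 nM.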

Compound 4, inhibition constant: 8500000 nM
For compound 4 the middle estimate is 12-fold (1.08 log units) below the measured one, and the stated range ends below it.
By their numbers in this assay, from the lowest: compounds 2 and 1 (each within the scatter of the next); then compounds 3 and 4 (each within the scatter of the next).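

The change of methoxy to hydroxymethyl on a saturated chain carbon bound to a carbonyl carbon gives a 14-fold higher number from compound 1 to compound 4 (1.15 log units; beyond the scatter) in this assay and thus weakens inhibition well beyond the scatter. Among these compounds, this is the first single change that can be read, and it shows that this place is sensitive to the exchange even though the two compounds hold the same atoms, joined differently. The count under this change differs in that hydroxymethyl carries 1 hydrogen-bond donor and methoxy 0, but nothing at hand ties the step to that difference or to any other cause.

From the compounds shown here alone, whether an amine, a carboxylic acid or a longer chain such as ethoxy at this place would keep or lose inhibition stays open. So does whether the same exchange would give a step of similar size on another core.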